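This account rests on a few compounds, and the source may have more. Where it says the series, first, only, none or still open, it means among the compounds named here.

Compound 2 `O=C1NCCN1c1ccc(S(=O)(=O)Nc2ccccc2)cc1` carries an unsubstituted phenyl on the sulfonamide nitrogen. Among the measured compounds shown here, in a functional assay on HT-29 cells (Homo sapiens) for antiproliferative activity, read by sulforhodamine B assay, with a stated time of 48 h (on this read-out lower numbers stand for stronger inhibition and higher numbers for weaker inhibition), compound 2 gives 280 nM, the lowest of the two numbers known here, although its nearest neighbour lies within the scatter. That neighbour, compound 1 `Cc1ccc(NS(=O)(=O)c2ccc(N3CCNC3=O)cc2)cc1`, gives 480 nM in this assay, and the step of a 1.7-fold lower number from compound 1 to compound 2 (0.23 log units; within the scatter). Compound 3 `CC(C)Cc1ccc(NS(=O)(=O)c2ccc(N3CCNC3=O)cc2)cc1` in this assay shows only > 1000 nM, which is a limit of the assay rather than a number. Relative to the two numbers, an at least 2.0-fold higher number from compound 1 to compound 3 (0.31 log units; beyond the scatter) and an at least 3.5-fold higher number from compound 2 to compound 3 (0.55 log units; beyond the scatter), so the larger group weakened the activity.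

Compound 4 `Cc1ccccc1NS(=O)(=O)c1ccc(N2CCNC2=O)cc1` differs from compound 2 by methyl in place of hydrogen on an aromatic carbon, the methyl sitting ortho to a large group. For the measured compounds named here, two measured steps bear on it: a methyl on this ring, at its earlier place, moved the number only within the scatter, while the isobutyl of compound 3 moved it beyond, though how far is hidden by the limit of > 1000 nM in this assay, at which 1 of the 3 values shown sits. A single methyl is the smaller of those two changes, so for compound 4 in this assay I expect a step of a 1.4-fold higher number from compound 2 to compound 4 (0.15 log units; within the scatter), at most a modest weakening. The estimated value for compound 4 is 400 nM, with a likely range from 180 nM to 1000 nM.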

Compound 4, half-maximal inhibitory concentration: 200 nM
Estimate against measurement, compound 4: 2.0-fold (0.30 log units) above; the measured number falls inside the stated range.
By their numbers in this assay, from the lowest: compounds 4, 2 and 1 (each within the scatter of the next, the first and the last beyond it). At a limit, above all of these: compound 3.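

A methyl ortho to a large group on the phenyl ring is accepted in this assay: a 1.4-fold lower number from compound 2 to compound 4 (0.15 log units; within the scatter), so compound 4 cannot be told apart from the unsubstituted compound 2. The new information comes from comparing the two methyl compounds, where moving the group on the ring attached to the sulfonamide nitrogen gives a 2.4-fold lower number from compound 1 to compound 4 (0.38 log units; beyond the scatter). Neither compound 1 nor compound 4 lies beyond the scatter from compound 2, yet these two lie beyond it from each other, which shows that the place of the methyl makes a modest difference that the earlier compounds could not reveal, although the numbers give no reason for it.

As far as these compounds go, it remains open whether an ethyl, a methoxy or an amine at this same place would keep the activity at this level, as a single small methyl does here. Compound 3 remains a limit rather than a number, so how far its isobutyl group moves the activity cannot be read: the limit of > 1000 nM in this assay, at which 1 of the 4 values shown sits.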